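Removing the phenoxypropyl chain from compound 2

A few compounds are considered here, and "the series" means these few. Any claim that something is new, unique, unknown or untested is made for them only; others in the source may bear on it.

Measured compounds:
compound 1 `Cc1ncsc1C(=O)Oc1ccc(-c2[nH]c3ccccc3c2C)cc1`, 13000 nM
compound 2 `Cc1c(-c2ccc(O)c(O)c2)n(CCCCOc2ccccc2)c2ccc(O)cc12`, 4300 nM
compound 3 `Cc1c(-c2ccc(O)cc2)n(CCCCOc2ccccc2)c2ccc(O)cc12`, 2000 nM

In a functional assay on A2780 cells (Homo sapiens) for inhibition, read by trypan blue exclusion, with a stated time of 72 h (a lower number here means a stronger inhibitor of growth, a higher number a weaker inhibitor of growth), compound 2 gives 4300 nM, the second highest of the three numbers. Its nearest neighbour is compound 3, which gives 2000 nM, a step of a 2.2-fold lower number from compound 2 to compound 3 (0.33 log units; beyond the scatter). Compound 1 gives 13000 nM, the highest number among the three.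

Compound 4 `Cc1c(-c2ccc(O)c(O)c2)n(C)c2ccc(O)cc12` has not been measured. It differs from compound 2 by hydrogen in place of 3-phenoxypropyl on a saturated chain carbon bound to an aromatic nitrogen. Going by the values given here, the one measured step, from compound 2 to compound 3, concerns a hydroxy on an aromatic carbon and not the chain on the aromatic nitrogen, so no measured step bears directly on this change. With nothing to anchor the direction, the expected step of a 1.4-fold higher number from compound 2 to compound 4 (0.14 log units; within the scatter) is given with a wide range. Compound 4 is therefore estimated at 6000 nM in this assay, expected to lie between 1500 nM and 25000 nM.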

Compound 4, concentration for 50% growth inhibition: 14000 nM
Estimate against measurement, compound 4: 2.3-fold (0.37 log units) below; the range from low to high includes it.
By their numbers in this assay, from the lowest: compound 3; then compound 2; then compounds 1 and 4 (each within the scatter of the next).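

Going by these compounds alone, this is the first measured change at this place, on a saturated chain carbon bound to an aromatic nitrogen; the earlier step concerned only a hydroxy on an aromatic carbon. In this assay, the step of a 3.3-fold higher number from compound 2 to compound 4 (0.51 log units; beyond the scatter) shows that with the catechol-bearing core held constant, hydrogen in place of 3-phenoxypropyl gives a weaker inhibitor of growth, so the chain contributes to the activity of compound 2 in this assay. No independent measurement shown here accounts for this loss.

The compounds shown leave open whether the benefit rests on the terminal phenyl ring, the ether oxygen or the chain length, since a plain butyl chain, a longer chain and a chain ending in an amine or a carboxylic acid do not appear among them. They also leave open whether the same change would give a similar step on the core of compound 3.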